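The source may report more compounds than this note shows. Statements on the series, on what has been measured and on what is new or still open speak of the compounds shown alone.

Measured compounds:
Compound 1 `CCC(=O)N(Cc1ccc(OC)c(O)c1)c1cc(OC)c(OC)c(OC)c1`: in a functional assay on KYSE-450 cells (Homo sapiens) for inhibition, read by MTT assay, with a stated time of 48 h (a higher number here means a weaker inhibitor, a lower number a stronger inhibitor), compound 1 gives 98 nM.
Compound 2 `COc1ccc(CNc2cc(OC)c(OC)c(OC)c2)cc1Br`: in this assay compound 2 gives 39800 nM.
Compound 3 `C=C(C)C(=O)N(Cc1ccc(OC)c(O)c1)c1cc(OC)c(OC)c(OC)c1`: in this assay compound 3 gives 200 nM.

Compound 3 stands second highest of the three numbers: compound 1 sits lower, and compound 2 sits far higher. Compound 4 `C/C=C/C(=O)N(Cc1ccc(OC)c(O)c1)c1cc(OC)c(OC)c(OC)c1` differs from compound 3 by prop-1-en-1-yl in place of 1-methylethenyl on a carbonyl carbon. Going by the values given here, the one measured step that bears on this is a 2.0-fold higher number from compound 1 to compound 3 (0.31 log units; beyond the scatter), which also changed the group on the same carbonyl carbon and moved the number only modestly. Rearranging the same three carbons on that carbonyl carbon is therefore expected to give a small step, if any, beyond the scatter, with direction uncertain. Compound 4 is estimated at 150 nM, within 60 nM to 450 nM. That estimate means an expected step of a 1.3-fold lower number from compound 3 to compound 4 (0.12 log units; within the scatter).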

Compound 4, half-maximal inhibitory concentration: 67 nM
Compound 4: the middle estimate sits 2.2-fold (0.35 log units) above what was measured; low and high end bracket the measured number.
By their numbers in this assay, from the lowest: compounds 4 and 1 (each within the scatter of the next); then compound 3; then compound 2.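

Moving the same three carbons from 1-methylethenyl to prop-1-en-1-yl on the carbonyl carbon gives a 3.0-fold lower number from compound 3 to compound 4 (0.47 log units; beyond the scatter) in this assay and so shows that the arrangement of these atoms matters, not only their count. Set against ethyl, prop-1-en-1-yl gives a 1.5-fold lower number from compound 1 to compound 4 (0.17 log units; within the scatter) and so shows that this double bond need not change the number. Nothing shown here explains the difference between the two arrangements. 

Going by these compounds, whether a longer chain such as butyl or a cyclopropyl ring would hold the number on this carbonyl carbon remains open. So does the effect of an amine there.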